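From a Dimethoxyphenyl to a Fluorophenyl Side Arm

The source may hold more compounds than are shown below. What is called first, only, known or untested is meant among the compounds shown, and "the series" means these compounds.

Compound 1 `COc1ccc(CN(C)c2cc(=O)c3cc(C(F)(F)F)cc([N+](=O)[O-])c3s2)cc1OC` and compound 2 `COc1ccc(CNc2cc(=O)c3cc(C(F)(F)F)cc([N+](=O)[O-])c3s2)cc1OC` share one core and differ only by hydrogen in place of methyl on a nitrogen on an aromatic ring. In an ADME assay on Vero cells (Chlorocebus sabaeus) for cytotoxicity, read by MTT assay, with a stated time of 48 h (a higher number here means a weaker inhibitor, a lower number a stronger inhibitor), compound 1 gives > 64 ug/mL, which is a limit of the assay rather than a number. In this assay compound 2 likewise gives > 64 ug/mL, again a limit. The step that the two limits leave unreadable from compound 1 to compound 2 therefore cannot be read, because both values sit at the limit of > 64 ug/mL in this assay, at which 2 of the 2 values shown sit. Within the data shown here, compound 2 thus stands at the limit of this assay with no number of its own, and the only further value shown is a limit as well.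

Compound 3 `O=c1cc(NCc2ccc(F)cc2)sc2c([N+](=O)[O-])cc(C(F)(F)F)cc12` differs from compound 2 by 4-fluorophenyl in place of 3,4-dimethoxyphenyl on a saturated chain carbon bound to a nitrogen on an aromatic ring. No measured step bears directly on this change; the single step shown was unreadable. With both neighbouring values at the limit, the expectation for this assay is that compound 3 stays close to that limit, the step that the limit leaves unreadable from compound 2 to compound 3 being expected to be none beyond the scatter. Compound 3 is therefore estimated at 70 ug/mL, within a range from 30 ug/mL to 150 ug/mL.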

Compound 3, half-maximal inhibitory concentration: > 64 ug/mL
Compound 3: a limit, no number; the forecaster's own chance of this, stated with the estimate: 70%; the middle value is on the limit's open side.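

In this assay compound 3 gives > 64 ug/mL as a limit of the assay and not a number. No step between compound 2 and compound 3 can be read, because both sit at the same limit: the limit of > 64 ug/mL in this assay, at which 3 of the 3 values shown sit.

The compounds shown leave open how 3,4-dimethoxyphenyl and 4-fluorophenyl compare in this assay once a value falls within the assay's range.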